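A few compounds are considered here, and "the series" means these few. Any claim that something is new, unique, unknown or untested is made for them only; others in the source may bear on it.

Measured compounds:
Compound 1 `C/C=C1/[C@H](O[C@@H]2O[C@H](CO)[C@@H](O)[C@H](O)[C@H]2O)OC=C(C(=O)OC)[C@H]1CC(=O)OCc1ccccc1` — in a functional assay on SK-BR-3 cells (Homo sapiens) for antiproliferative activity, read by MTT assay, with a stated time of 72 h (on this read-out higher numbers stand for weaker inhibition and lower numbers for stronger inhibition), compound 1 gives > 15000 nM, which is a limit of the assay and not a number.
Compound 2 `C/C=C1/[C@H](O[C@@H]2O[C@H](COC(C)=O)[C@@H](OC(C)=O)[C@H](OC(C)=O)[C@H]2OC(C)=O)OC=C(C(=O)OC)[C@H]1CC(=O)SCCC` — in this assay compound 2 gives > 15000 nM, again only a limit.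
Compound 3 `C=CCOC(=O)C[C@@H]1C(C(=O)OC)=CO[C@@H](O[C@@H]2O[C@H](COC(C)=O)[C@@H](OC(C)=O)[C@H](OC(C)=O)[C@H]2OC(C)=O)/C1=C/C` — in this assay compound 3 gives > 20000 nM, also a limit.

Compound 1 thus stands at a limit: the numbers show only that its inhibition was too weak to be resolved, and the two other values shown are limits as well. Compound 4 `C/C=C1/[C@H](O[C@@H]2O[C@H](CO)[C@@H](O)[C@H](O)[C@H]2O)OC=C(C(=O)OC)[C@H]1CC(=O)OCc1ccc2c(c1)OCCO2` differs from compound 1 in one place: 2,3-dihydro-1,4-benzodioxin-6-yl in place of phenyl on a saturated chain carbon bound to an oxygen next to a carbonyl group. For the measured compounds named here, the only measured step is a step that the two limits leave unreadable from compound 2 to compound 3, and it cannot be read because the limit of > 15000 nM in this assay, at which 2 of the 3 values shown sit, and the limit of > 20000 nM in this assay, at which 1 of the 3 values shown sits, cap both of its ends; it also concerns a different place on the shared core. No measured step touches the benzyl group of compound 1, so nothing shown tells how the change to compound 4 should move the read-out. What the three compounds have in common is that each returns only a limit. The step that the limit leaves unreadable from compound 1 to compound 4 is therefore expected to be one that the assay cannot resolve, with compound 4 expected to return a limit too. Compound 4 is estimated at 20000 nM, between 7000 nM and 60000 nM.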

Compound 4, half-maximal inhibitory concentration: > 15000 nM
Compound 4: only a limit was reported; the forecaster's own chance of this, stated with the estimate: 80%; the middle value does not contradict the limit.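

In this assay compound 4 gives > 15000 nM as a limit and not a number. The step from compound 1 to compound 4 therefore cannot be read, since both ends sit at the same limit: the limit of > 15000 nM in this assay, at which 3 of the 4 values shown sit. The compounds shown leave open how strongly any of them inhibits, and whether 2,3-dihydro-1,4-benzodioxin-6-yl in place of phenyl changes that at all.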